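Swapping Benzylamino for 1-Hydroxy-1-methylethyl on the Shared Core

A few compounds are considered here, and "the series" means these few. Any claim that something is new, unique, unknown or untested is made for them only; others in the source may bear on it.

Going by the values given here, compound 2 `Cc1noc(NS(=O)(=O)c2cccc3c(NCc4ccccc4)cccc23)c1C` gives 590 nM in an assay on VSM-A10 cells for antagonist activity at Endothelin-1 receptor (Rattus norvegicus) (a higher number here means a weaker inhibitor, a lower number a stronger inhibitor), the lowest of the two numbers measured so far; its nearest neighbour is compound 1 `Cc1noc(NS(=O)(=O)c2cccc3c(NC(=O)C(C)C)cccc23)c1C`, which gives 880 nM, and the step of a 1.5-fold lower number from compound 1 to compound 2 (0.17 log units; within the scatter) lies within the scatter. Compound 3 `Cc1noc(NS(=O)(=O)c2cccc3c(C(C)(C)O)cccc23)c1C` has not yet been measured. The change from compound 2 to compound 3 is 1-hydroxy-1-methylethyl in place of benzylamino on an aromatic carbon. Among the compounds with values here, the one measured step, a 1.5-fold lower number from compound 1 to compound 2 (0.17 log units; within the scatter), is of a different kind: it exchanged one group for another on a nitrogen that stayed in place, whereas here the nitrogen itself leaves and a much smaller group carrying a hydroxyl enters. That step therefore gives only loose guidance, and the expectation rests mainly on the removal of a large part of the group. A modest weakening is expected, a step of a 2.2-fold higher number from compound 2 to compound 3 (0.34 log units; beyond the scatter). Compound 3 is estimated at 1300 nM, within a range from 400 nM to 4000 nM.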

Compound 3, half-maximal inhibitory concentration: 2890 nM
The estimate for compound 3 lay 2.2-fold (0.35 log units) below the measured number, within the range that was stated.
By their numbers in this assay, from the lowest: compounds 2 and 1 (each within the scatter of the next); then compound 3.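

Changing the atom that joins the group to this aromatic carbon moves the number clearly in this assay: the change from benzylamino to 1-hydroxy-1-methylethyl gives a 4.9-fold higher number from compound 2 to compound 3 (0.69 log units; beyond the scatter), and the change from (isopropylcarbonyl)amino gives a 3.3-fold higher number from compound 1 to compound 3 (0.52 log units; beyond the scatter), whereas the earlier exchange on the retained nitrogen stayed within the scatter. Benzylamino and 1-hydroxy-1-methylethyl have the same counts of hydrogen-bond donors and acceptors, so those counts do not distinguish the pair, although the entering group is smaller and has no ring. No measurement here explains the weakening.

Loss of the nitrogen, loss of the ring and the drop in size all occur together in compound 3, so their separate contributions remain unknown. A plain amine or a benzyloxy group on this carbon would help to pull them apart.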